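Phenyl-substituted tetrahydropyrans in a cytotoxicity series

The source may hold more compounds than are shown below. What is called first, only, known or untested is meant among the compounds shown, and "the series" means these compounds.

Three compounds of this series carry a measured number in a functional assay on HeLa cells (Homo sapiens) for cytotoxicity, read by WST assay, with a stated time of 48 h; on this read-out higher numbers stand for weaker inhibition and lower numbers for stronger inhibition. Compound 1 `COc1cccc(/C=C/C[C@@H]2C[C@@H]([C@@H](O)c3ccc(OC)c(OC)c3)CO[C@H]2c2ccc(OC)c(OC)c2)c1` gives 16400 nM, compound 2 `COc1ccccc1/C=C/C[C@H]1C[C@@H]([C@@H](O)c2ccccc2)CO[C@@H]1c1ccccc1` gives 14700 nM, and compound 3 `COc1ccc(/C=C/C[C@@H]2C[C@H]([C@H](O)c3ccc(OC)c(OC)c3)CO[C@H]2c2ccc(OC)c(OC)c2)cc1OC` gives 28700 nM. Compound 2 holds the smallest of the three numbers, yet both others fall within the scatter of it, so the three stand level. The next compound, compound 4 `O[C@@H](c1ccccc1)[C@H]1CO[C@H](c2ccccc2)[C@@H](C/C=C/c2ccc(F)cc2)C1`, is not yet measured in this assay. It differs from compound 2 by 4-fluorophenyl in place of 2-methoxyphenyl on a double-bonded chain carbon bound to a double-bonded chain carbon. For the measured compounds named here, no pair of measured compounds shows a single change of this kind, and the three measured numbers sit close together. The step from compound 2 to compound 4 is therefore expected to stay within the scatter, a 1.2-fold higher number from compound 2 to compound 4 (0.06 log units; within the scatter). Compound 4 is estimated at 17000 nM, with a range of 7000 nM to 40000 nM.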

Compound 4, half-maximal inhibitory concentration: 8340 nM
Beside the measured number, compound 4's estimate is 2.0-fold (0.31 log units) above it, and the stated range covers the measured number.
By their numbers in this assay, from the lowest: compounds 4, 2, 1 and 3 (each within the scatter of the next, the first and the last beyond it).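

The first step read at a single place, a 1.8-fold lower number from compound 2 to compound 4 (0.25 log units; within the scatter), lies within the scatter. On this one pair, 4-fluorophenyl and 2-methoxyphenyl on a double-bonded chain carbon bound to a double-bonded chain carbon are therefore not told apart, although the group that enters has no hydrogen-bond acceptor and the group that leaves has one. No measurement here accounts for the result.

For the compounds shown here, open is how far this holds beyond the one pair, since the fluorine and the methoxy group change together. An unsubstituted phenyl or an aminophenyl at this place would test that.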